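Replacing the aryl amide with a dimethylaminoethyl amide

The source may report more compounds than this note shows. Statements on the series, on what has been measured and on what is new or still open speak of the compounds shown alone.

Of the compounds shown here, three sharing one core have been measured in an assay on isolated protein for inhibition of glutathione S-transferase P (Homo sapiens), with a stated time of 10 min; a lower number here means a stronger inhibitor, a higher number a weaker inhibitor. Compound 1 `O=C(CCC(=O)OCCCCCCSc1ccc([N+](=O)[O-])c2nonc12)Nc1ccccc1F` gives 9890 nM. Compound 2 `O=C(CCC(=O)OCCCCCCSc1ccc([N+](=O)[O-])c2nonc12)Nc1ccc(F)c(Cl)c1` gives 9850 nM, and compound 3 `CCN(CC)CCCNC(=O)CCC(=O)OCCCCCCSc1ccc([N+](=O)[O-])c2nonc12` gives 9550 nM. Compound 1 is indistinguishable from either neighbour: the step of a 1.0-fold lower number from compound 1 to compound 2 (0.00 log units; within the scatter) and the step of a 1.0-fold lower number from compound 1 to compound 3 (0.02 log units; within the scatter) are both within the scatter, as is a 1.0-fold lower number from compound 2 to compound 3 (0.01 log units; within the scatter).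

The next compound, compound 4 `CN(C)CCNC(=O)CCC(=O)OCCCCCCSc1ccc([N+](=O)[O-])c2nonc12`, differs from compound 1 in the group on the amide-type nitrogen: 2-(dimethylamino)ethyl in place of 2-fluorophenyl on an amide-type nitrogen. The step that bears most directly on it is a 1.0-fold lower number from compound 1 to compound 3 (0.02 log units; within the scatter), in which an aryl group on that nitrogen gave way to a 3-(diethylamino)propyl chain with no change beyond the scatter; the step of a 1.0-fold lower number from compound 1 to compound 2 (0.00 log units; within the scatter) likewise shows that swapping one aryl group for another left the number where it was. Among the measured compounds shown here, a 2-(dimethylamino)ethyl group is a shorter chain of the same kind as the one in compound 3, so no step beyond the scatter is expected in this assay in either direction.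

Compound 4 is therefore expected to give 9700 nM, with a likely range from 5000 nM to 19000 nM. The expected step of a 1.0-fold lower number from compound 1 to compound 4 (0.01 log units; within the scatter) would leave compound 4 within the scatter of compound 1.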

Compound 4, half-maximal inhibitory concentration: 540 nM
Estimate against measurement, compound 4: 18-fold (1.25 log units) above; the whole stated range lies above it.
By their numbers in this assay, from the lowest: compound 4; then compounds 3, 2 and 1 (each within the scatter of the next).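

The group on the amide-type nitrogen is not indifferent in this assay, as the three earlier compounds had suggested: the 2-(dimethylamino)ethyl group stands apart from both aryl groups, with an 18-fold lower number from compound 1 to compound 4 (1.26 log units; beyond the scatter) and an 18-fold lower number from compound 2 to compound 4 (1.26 log units; beyond the scatter). Having an amine-bearing chain at this position is not enough in itself, since the step of an 18-fold lower number from compound 3 to compound 4 (1.25 log units; beyond the scatter) separates two such chains, and compound 3 stays within the scatter of the two aryl compounds. No measurement shown here gives a reason for these steps.

The step between the two chains changes the chain length and the groups on the amine together, so the compounds shown do not tell which of the two matters. From the compounds shown here alone, a 3-(dimethylamino)propyl group and a 2-(diethylamino)ethyl group, each changing only one of these features, would separate them, and it remains open whether the effect of the 2-(dimethylamino)ethyl group extends to any other amine on a chain of that kind, such as a pyrrolidine.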